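This account rests on a few compounds, and the source may have more. Where it says the series, first, only, none or still open, it means among the compounds named here.

Two amides of the shared core have been measured in a functional assay on A549 cells (Homo sapiens) for inhibition, read by sulforhodamine B assay, with a stated time of 72 h; a higher number here means a weaker inhibitor, a lower number a stronger inhibitor. Compound 1 (`Nc1sc(-c2ccc(Cl)cc2)c(-c2ccc(Cl)cc2)c1C(=O)N1CCCCC1`) gives 4620 nM, and compound 2 (`Nc1sc(-c2ccc(Cl)cc2)c(-c2ccc(Cl)cc2)c1C(=O)N1CCOCC1`) gives 1870 nM, the lower of the two numbers and so the stronger inhibitor of this pair. Compound 3 (`Nc1sc(-c2ccc(Cl)cc2)c(-c2ccc(Cl)cc2)c1C(=O)N1CCCC1`) keeps the core and changes only the amide ring: pyrrolidin-1-yl in place of morpholin-4-yl on a carbonyl carbon. Among the measured compounds shown here, one measured step bears on this change, a 2.5-fold lower number from compound 1 to compound 2 (0.39 log units; beyond the scatter), where morpholin-4-yl replaced piperidin-1-yl on the same carbonyl carbon. For the measured compounds named here, that step was modest, and it is the only guide, since no five-membered ring has been measured yet. Pyrrolidin-1-yl resembles piperidin-1-yl more closely than morpholin-4-yl does, so part of that step is expected to reverse in this assay. The expected change is a 1.7-fold higher number from compound 2 to compound 3 (0.23 log units; within the scatter), a small move towards a higher number. For compound 3 the estimated value is 3200 nM, with an expected range from 1400 nM to 7000 nM.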

Compound 3, half-maximal inhibitory concentration: 890 nM
The estimate for compound 3 lay 3.6-fold (0.56 log units) above the measured number; the whole stated range lies above it.
By their numbers in this assay, from the lowest: compound 3; then compound 2; then compound 1.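

In this assay, pyrrolidin-1-yl on the carbonyl carbon gives the strongest inhibitor of the three amides, beating morpholin-4-yl (a 2.1-fold lower number from compound 2 to compound 3 (0.32 log units; beyond the scatter)) and piperidin-1-yl (a 5.2-fold lower number from compound 1 to compound 3 (0.72 log units; beyond the scatter)). The ring oxygen of morpholin-4-yl is therefore not needed for a lower number. The two rings without that oxygen sit at opposite ends of the series, so the presence or absence of oxygen does not set the order by itself, and the amide ring matters more at this position than the first pair suggested. Nothing available explains this order. On these data alone, it remains open whether a smaller azetidin-1-yl ring would lower the number further, or whether an open-chain diethylamino group would do as well as a ring. A piperazin-1-yl ring, with a second nitrogen, is also untested among these compounds.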